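Moving the Substituent Around the Benzyl Ring

This account rests on a few compounds, and the source may have more. Where it says the series, first, only, none or still open, it means among the compounds named here.

Compound 1 `O=c1cc(CN(Cc2ccccc2)c2cnccn2)c2ccc(F)c(F)c2[nH]1`: 13 nM
Compound 2 `O=c1cc(CN(Cc2ccccc2Cl)c2cnccn2)c2ccc(F)c(F)c2[nH]1`: 12 nM
Compound 3 `O=c1cc(CN(Cc2ccc(Cl)cc2)c2cnccn2)c2ccc(F)c(F)c2[nH]1`: 77 nM

In an assay on HEK293 cells for inhibition of Nitric oxide synthase, inducible (Homo sapiens), read by fluorescence (on this read-out higher numbers stand for weaker inhibition and lower numbers for stronger inhibition), compound 3 stands at the highest number of the three, its nearest neighbour being compound 1, while compound 2 lies furthest from it. Compound 4 `Cc1ccccc1CN(Cc1cc(=O)[nH]c2c(F)c(F)ccc12)c1cnccn1` differs from compound 3 by 2-methylphenyl in place of 4-chlorophenyl on a saturated chain carbon bound to a nitrogen on an aromatic ring. Within the data shown here, two measured steps bear on this change. Moving the chloro from the position it holds in compound 2 to the one it holds in compound 3 gave a 6.4-fold higher number from compound 2 to compound 3 (0.81 log units; beyond the scatter), and adding chloro at that same position gave a 5.9-fold higher number from compound 1 to compound 3 (0.77 log units; beyond the scatter), whereas adding it at the position held in compound 2 gave a 1.1-fold lower number from compound 1 to compound 2 (0.03 log units; within the scatter). Compound 4 carries its substituent at the position of compound 2, so a return toward the numbers of compounds 1 and 2 is expected, with the methyl in place of chloro adding some uncertainty. The step is therefore estimated as a 4.8-fold lower number from compound 3 to compound 4 (0.68 log units; beyond the scatter). Compound 4 is accordingly expected at 16 nM, within a range of 7 nM to 40 nM.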

Compound 4, half-maximal inhibitory concentration: 10 nM
Estimate against measurement, compound 4: 1.6-fold (0.20 log units) above, within the range that was stated.
By their numbers in this assay, from the lowest: compounds 4, 2 and 1 (each within the scatter of the next); then compound 3.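

In this assay, exchanging the 4-chlorophenyl group for 2-methylphenyl gave a 7.7-fold lower number from compound 3 to compound 4 (0.89 log units; beyond the scatter). Set against the 2-chlorophenyl group of compound 2, methyl in place of chloro gave a 1.2-fold lower number from compound 2 to compound 4 (0.08 log units; within the scatter), and set against the unsubstituted ring of compound 1, methyl in place of hydrogen gave a 1.3-fold lower number from compound 1 to compound 4 (0.11 log units; within the scatter), so methyl, chloro and hydrogen do not separate across compounds 1, 2 and 4, and compound 3 alone stands apart. Nothing measured here explains why compound 3 differs from the others.

On these data alone, what remains open is whether a 4-methylphenyl group would follow the 4-chlorophenyl group of compound 3 or the 2-methylphenyl group of compound 4. Also open, as far as these compounds go, is how a methoxy group or an aminomethyl group on this ring would read.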